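This account rests on a few compounds, and the source may have more. Where it says the series, first, only, none or still open, it means among the compounds named here.

Of the compounds shown here, three sharing one core have been read in a functional assay on HeLa cells (Homo sapiens) for cytotoxicity, read by MTT assay, with a stated time of 72 h; a higher number here means a weaker inhibitor, a lower number a stronger inhibitor. Compound 1 `CC(C)(C)NC(=S)N/N=C1\CC(c2ccc(O)cc2)Oc2cc(O)ccc21` gives 50000 nM, and compound 2 `Oc1ccc(C2C/C(=N\NC(=S)N3CCCC3)c3ccc(O)cc3O2)cc1` gives 65200 nM. The measured step between them is a 1.3-fold higher number from compound 1 to compound 2 (0.12 log units; within the scatter), so these two cannot be told apart. Compound 3 `CCCCNC(=S)N/N=C1\CC(c2ccc(O)cc2)Oc2cc(O)ccc21` gives > 100000 nM, which is a limit of the assay and not a number. Compound 3 therefore has no exact place on the scale, only a bound.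

Compound 4 `CCCN(CCC)C(=S)N/N=C1\CC(c2ccc(O)cc2)Oc2cc(O)ccc21` differs from compound 3 in one place, with dipropylamino in place of butylamino on a thiocarbonyl carbon. The closest guide is a change at the same carbon, where butylamino took the place of pyrrolidin-1-yl, giving an at least 1.5-fold higher number from compound 2 to compound 3 (0.18 log units; that floor lies within the scatter). Replacing tert-butyl with butyl gave an at least 2.0-fold higher number from compound 1 to compound 3 (0.30 log units; that floor lies within the scatter). Both are bounds rather than exact sizes, and neither establishes a real effect. Since butylamino now leaves, a small move toward a lower number in this assay is expected, perhaps none beyond the scatter. The expected step is an at least 1.4-fold lower number from compound 3 to compound 4 (0.15 log units; that floor lies within the scatter). Compound 4 could also end at the limit of > 100000 nM in this assay, at which 1 of the 3 values shown sits. Compound 4 is estimated at 70000 nM, with an expected range from 30000 nM to 100000 nM.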

Compound 4, half-maximal inhibitory concentration: 75300 nM
Compound 4: middle estimate off by 1.1-fold (0.03 log units), on the low side, and the stated range covers the measured number.
By their numbers in this assay, from the lowest: compounds 1, 2 and 4 (each within the scatter of the next). At a limit, above all of these: compound 3.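

In this assay the swap of butylamino for dipropylamino on a thiocarbonyl carbon removes the hydrogen-bond donor of butylamino and gives an at least 1.3-fold lower number from compound 3 to compound 4 (0.12 log units; that floor lies within the scatter), so no real effect of this change is established. Set against the other two compounds, dipropylamino gives a 1.2-fold higher number from compound 2 to compound 4 (0.06 log units; within the scatter) and a 1.5-fold higher number from compound 1 to compound 4 (0.18 log units; within the scatter), which means that dipropylamino, pyrrolidin-1-yl and (tert-butyl)amino cannot be told apart at this carbon, and compound 4 adds a third measured number to that group. Compound 3 remains the only one without a place on the scale, and its value is a limit and not a number: the limit of > 100000 nM in this assay, at which 1 of the 4 values shown sits.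

From the compounds shown here alone, what a ring such as morpholin-4-yl or a longer chain such as dihexylamino would do on this thiocarbonyl carbon stays open, as does whether any group there can shift the number beyond the scatter. The shared core is the same in all four compounds, so the result of a change there, such as methoxy in place of a hydroxyl group, is also unknown.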